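Bromo in Place of Methoxy: Cytotoxicity Expected Unchanged

The source may hold more compounds than are shown below. What is called first, only, known or untested is meant among the compounds shown, and "the series" means these compounds.

Compound 1, `COc1ccc(C[C@H]2COC(=O)[C@@H]2Cc2ccc(OCC(=O)Nc3ccccc3)c(OC)c2)cc1OC`, gives >= 600000 nM in an ADME assay on HeLa cells (Homo sapiens) for cytotoxicity, read by MTT assay (a lower number here means a stronger inhibitor, a higher number a weaker inhibitor), a limit of the assay. Compound 2, `COc1ccc(C[C@H]2COC(=O)[C@@H]2Cc2ccc(OCc3cn(-c4cccc(Cl)c4)nn3)c(OC)c2)cc1OC`, gives 493000 nM. Compound 3, `COc1ccc(-n2cc(COc3ccc(C[C@H]4C(=O)OC[C@@H]4Cc4ccc(OC)c(OC)c4)cc3OC)nn2)cc1`, gives >= 600000 nM, again a limit of the assay.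

Compound 3 thus stands at the ceiling, (the limit of >= 600000 nM in this assay, at which 2 of the 3 values shown sit), with no number of its own. Compound 4, `COc1ccc(C[C@H]2COC(=O)[C@@H]2Cc2ccc(OCc3cn(-c4ccc(Br)cc4)nn3)c(OC)c2)cc1OC`, differs from it by bromo in place of methoxy on an aromatic carbon. Going by the values given here, two measured steps bear on this region: an at least 1.2-fold lower number from compound 1 to compound 2 (0.08 log units; that floor lies within the scatter) and an at least 1.2-fold higher number from compound 2 to compound 3 (0.08 log units; that floor lies within the scatter), both sitting within the scatter. Among the compounds with values here, no measured step swaps bromo for methoxy, so the expectation rests on the flatness seen so far: no step beyond the scatter, an at least 1.0-fold lower number from compound 3 to compound 4 (0.02 log units; that floor lies within the scatter). Compound 4 is therefore estimated at 560000 nM, with a range from 300000 nM to 650000 nM, most likely reported only as a limit.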

Compound 4, half-maximal inhibitory concentration: 128000 nM
Compound 4: middle estimate off by 4.4-fold (0.64 log units), on the high side; the whole stated range lies above it.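

This position is not flat in this assay: bromo in place of methoxy gives an at least 4.6-fold lower number from compound 3 to compound 4 (0.67 log units; beyond the scatter). The 4-bromophenyl group also gives a 3.9-fold lower number from compound 2 to compound 4 (0.59 log units; beyond the scatter), and the whole 1-(4-bromophenyl)-1H-1,2,3-triazol-4-yl group gives an at least 4.6-fold lower number from compound 1 to compound 4 (0.67 log units; beyond the scatter). Two of these steps start from a limit of the assay, not a number, so their true size stays unknown: the limit of >= 600000 nM in this assay, at which 2 of the 4 values shown sit.

Still open, from the compounds shown here alone, is whether bromo is special here, or whether fluoro, chloro or an amine on the same aromatic carbon would give a similarly low number.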